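The source may report more compounds than this note shows. Statements on the series, on what has been measured and on what is new or still open speak of the compounds shown alone.

Measured in a functional assay on PC-3 cells (Homo sapiens) for cytotoxicity, read by WST assay, with a stated time of 72 h; a higher number here means a weaker inhibitor, a lower number a stronger inhibitor:

Compound 1 `CCCCCOc1ccc(C2(c3ccc(O)cc3)C(=O)Nc3c2ccc(F)c3F)cc1` gives > 1000 nM (a limit)
Compound 2 `COc1ccc(C2(c3cccc(O)c3)C(=O)Nc3c2ccc(F)c3F)cc1` gives 145 nM
Compound 3 `O=C1Nc2c(ccc(F)c2F)C1(c1ccc(O)cc1)c1ccc(F)c(F)c1` gives 19 nM

Compound 1 is reported only as a limit, at > 1000 nM (not as a number). That leaves two true numbers in the set. Of these, compound 3 stands lowest at 19 nM and so is the stronger inhibitor of the two, while compound 2 reads 145 nM with a gap between them that lies beyond the scatter.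

The next compound to be tested is compound 4 `O=C1Nc2c(ccc(F)c2F)C1(c1ccc(O)cc1)C1CCCCCC1` in the same assay. It carries cycloheptyl in place of 3,4-difluorophenyl on a saturated ring carbon, two ring bonds from the ring nitrogen cycloheptyl in place of 3,4-difluorophenyl on a saturated ring carbon and keeps the rest of compound 3 unchanged. Going by the values given here, none of the measured compounds carries a cycloheptyl group, and no measured pair isolates a change at this carbon, so the expectation is loose. Compound 3 sits low at 19 nM in this assay and a new group there seems more likely to raise the number than to lower it. The expected change is a modest weakening, estimated as a 3.2-fold higher number from compound 3 to compound 4 (0.50 log units; beyond the scatter) and only just beyond the scatter. Compound 4 is estimated at 60 nM with an expected range from 10 nM to 400 nM.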

Compound 4, half-maximal inhibitory concentration: 12 nM
Estimate against measurement, compound 4: 5.0-fold (0.70 log units) above; the range from low to high includes it.
By their numbers in this assay, from the lowest: compounds 4 and 3 (each within the scatter of the next); then compound 2. At a limit, above all of these: compound 1.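

The step of a 1.6-fold lower number from compound 3 to compound 4 (0.20 log units; within the scatter) in this assay is the only pair shown that isolates this saturated ring carbon, two ring bonds from the ring nitrogen. With cycloheptyl in place of 3,4-difluorophenyl the two compounds read alike, so for this pair neither the six-membered aromatic ring of carbon only nor the two fluorine atoms of the departing group are needed for a low number, and a seven-membered non-aromatic ring of carbon only serves equally well at this carbon. Nothing measured in this set offers a reason why two such different groups should read alike.

The compounds shown leave open how far this tolerance reaches: whether a smaller ring such as cyclopentyl, or an open chain such as hexyl, would also read alike at this carbon. As far as these compounds go, it is also open whether a ring carrying an amine or a carboxylic acid, or a piperidine ring with its own ring nitrogen, would be accepted here as cycloheptyl is.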